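Hydroxy for Amino on a Four-Carbon Chain

A few compounds are considered here, and "the series" means these few. Any claim that something is new, unique, unknown or untested is made for them only; others in the source may bear on it.

Compound 1 `NCCCCNc1nc(Nc2ccc(Oc3nccs3)cc2)c2ncn(C3CCCC3)c2n1` and compound 2 `OCCCCNc1nc(Nc2ccc(Oc3nccs3)cc2)c2ncn(C3CCCC3)c2n1` share one core and differ only at the end of a side chain. In an ADME assay on CCRF-CEM cells (Homo sapiens) for inhibition, read by fluorescence and resazurin assay, with a stated time of 72 h (on this read-out lower numbers stand for stronger inhibition of growth and higher numbers for weaker inhibition of growth), compound 1 gives 8640 nM, and compound 2 gives 13400 nM. The change between them is hydroxy in place of amino on a saturated chain carbon, four bonds along the chain from a nitrogen on an aromatic ring, and it made a 1.6-fold higher number from compound 1 to compound 2 (0.19 log units; within the scatter).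

Compound 3 `NCCCCNc1nc(Nc2ccc(N3CCN(Cc4ccccc4)CC3)cc2)c2ncn(CCCO)c2n1` carries a different core; how the two cores differ is not broken down here. In this assay compound 3 gives 7570 nM, a number that lies within the scatter of both compound 1 and compound 2.

Compound 4 `OCCCCNc1nc(Nc2ccc(N3CCN(Cc4ccccc4)CC3)cc2)c2ncn(CCCO)c2n1` has not yet been measured in this assay. Compared with compound 3 the change is hydroxy in place of amino on a saturated chain carbon, four bonds along the chain from a nitrogen on an aromatic ring, the same change that turns compound 1 into compound 2, at the same place on the chain. Among the compounds with values here, since the only known example of this change is the step of a 1.6-fold higher number from compound 1 to compound 2 (0.19 log units; within the scatter), which stayed within the scatter, the expected step from compound 3 to compound 4 is a 1.6-fold higher number from compound 3 to compound 4 (0.20 log units; within the scatter), a small one that rests on that single pair and on the value of compound 3, 7570 nM. On that basis compound 4 is estimated to give 12000 nM in this assay. For compound 4 the estimated range runs from 6000 nM to 25000 nM, and the true number for compound 4 is now awaited.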

Compound 4, concentration for 50% growth inhibition: 27900 nM
Compound 4: middle estimate off by 2.3-fold (0.37 log units), on the low side; measured number outside the range, above it.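

In this assay, hydroxy in place of amino at the same place on the chain gave a 3.7-fold higher number from compound 3 to compound 4 (0.57 log units; beyond the scatter), while on the other core the same change gave a 1.6-fold higher number from compound 1 to compound 2 (0.19 log units; within the scatter). The two steps run the same way, and the gap between them is too small to set them apart: the same change on two cores in this assay, a 1.6-fold higher number (0.19 log units; within the scatter) from compound 1 to compound 2 and a 3.7-fold higher number (0.57 log units; beyond the scatter) from compound 3 to compound 4, 2.4-fold (0.38 log units) apart, within the scatter of two such steps

Within the data shown here, this shows that the change carried over in direction across these two cores, although only the step on the core of compound 3 lies beyond the usual scatter, and it gives no grounds for saying that the core alters the size of the step; it also does not show that the size is the same on both cores, and two pairs say nothing about any further core.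

The compounds shown leave open how a carboxylic acid or a methyl ether at the end of the chain, or a longer chain carrying the amino or hydroxy group, would read in this assay. They also leave open which of the parts that separate the two cores, if any, bears on the size of the step.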